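Sulfonyl aryl variation on the shared core: chloro to bromo

This account rests on a few compounds, and the source may have more. Where it says the series, first, only, none or still open, it means among the compounds named here.

Measured so far in a functional assay on HepG2 cells (Homo sapiens) for antiproliferative activity, with a stated time of 72 h; on this read-out lower numbers stand for an effect already at smaller amounts and higher numbers for an effect only at larger amounts of compound:
- Compound 1 `COc1ccc(-c2cc(=O)c3c(OC)cc(OC)cc3n2S(=O)(=O)c2cccc([N+](=O)[O-])c2)cc1`: compound 1 reaches only the limit > 39600 nM.
- Compound 2 `COc1ccc(-c2cc(=O)c3c(OC)cc(OC)cc3n2S(=O)(=O)c2ccc(C)c([N+](=O)[O-])c2)cc1`: compound 2 reaches only the limit > 51700 nM.
- Compound 3 `COc1ccc(-c2cc(=O)c3c(OC)cc(OC)cc3n2S(=O)(=O)c2ccc(Cl)cc2)cc1`: compound 3 reaches only the limit > 34400 nM.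

Compound 3 stands at a limit in this assay, and so do the other two values shown (the limit of > 34400 nM in this assay, at which 1 of the 3 values shown sits, (the limit of > 39600 nM in this assay, at which 1 of the 3 values shown sits), (the limit of > 51700 nM in this assay, at which 1 of the 3 values shown sits)). Nothing orders the three compounds against one another. The steps a step that the two limits leave unreadable from compound 1 to compound 2, a step that the two limits leave unreadable from compound 1 to compound 3 and a step that the two limits leave unreadable from compound 2 to compound 3 are all unreadable because of the limit of > 34400 nM in this assay, at which 1 of the 3 values shown sits, the limit of > 39600 nM in this assay, at which 1 of the 3 values shown sits, and the limit of > 51700 nM in this assay, at which 1 of the 3 values shown sits, leave no number to compare.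

Compound 4 `COc1ccc(-c2cc(=O)c3c(OC)cc(OC)cc3n2S(=O)(=O)c2ccc(Br)cc2)cc1` differs from compound 3 in one place: bromo in place of chloro on an aromatic carbon. Among the measured compounds shown here, no measured step touches this halogen swap, and no step is readable at all. What the three limits show is a series that gives no measurable effect in this assay up to the amounts tested, across nitro, methyl-nitro and chloro substitution of the sulfonyl aryl. The expectation for the bromo analogue therefore rests only on that silence: the step that the limit leaves unreadable from compound 3 to compound 4 is expected to be none beyond the scatter, most probably another limit.

Compound 4 is estimated at 45000 nM in this assay, with a range from 12000 nM to 150000 nM.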

Compound 4, half-maximal effective concentration: 16300 nM
Compound 4: middle estimate off by 2.8-fold (0.44 log units), on the high side, within the range that was stated.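

In this assay, among the compounds shown here, compound 4 gives 16300 nM, the first number that is not a limit, and it shows that this place on the sulfonyl aryl ring, para to a large group, responds to a change of halogen alone: the swap of chloro for bromo gives an at least 2.1-fold lower number from compound 3 to compound 4 (0.32 log units; beyond the scatter). The 4-bromophenyl group also separates from both nitro-bearing sulfonyl aryl groups, with an at least 3.1-fold lower number from compound 2 to compound 4 (0.50 log units; beyond the scatter) and with an at least 2.4-fold lower number from compound 1 to compound 4 (0.38 log units; beyond the scatter). These three steps give only minimum sizes, and the closest comparison still rests on the limit of compound 3: the limit of > 34400 nM in this assay, at which 1 of the 4 values shown sits.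

The steps among compound 1, compound 2 and compound 3 remain unreadable, so the true size of the bromo effect is unknown, and the compounds shown cannot tell whether the change follows halogen size or is particular to bromo. Also open, from the compounds shown here alone, is how this place would respond to iodo, to trifluoromethyl or to an amine or a carboxylic acid in place of bromo.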